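From methoxycarbonyl to methyl on an aromatic carbon

The source may report more compounds than this note shows. Statements on the series, on what has been measured and on what is new or still open speak of the compounds shown alone.

Compound 1 `COc1cc2oc(-c3cccc(NC(=O)c4cccc(C#N)c4)c3)cc(=O)c2c(OC)c1OC`: 11900 nM
Compound 2 `COC(=O)c1ccc(C(=O)Nc2cccc(-c3cc(=O)c4c(OC)c(OC)c(OC)cc4o3)c2)cc1`: > 100000 nM

In a functional assay on HepG2 cells (Homo sapiens) for inhibition, read by MTT assay (on this read-out higher numbers stand for weaker inhibition of growth and lower numbers for stronger inhibition of growth), compound 2 gives > 100000 nM, which is a limit of the assay and not a number. In this assay compound 1, by contrast, gives a measured 11900 nM.

Compound 3 `COc1cc2oc(-c3cccc(NC(=O)c4ccc(C)cc4)c3)cc(=O)c2c(OC)c1OC` has not yet been measured. It differs from compound 2 in one place: methyl in place of methoxycarbonyl on an aromatic carbon.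

Within the data shown here, one measured step bears on this change, though only indirectly. The step of an at least 8.4-fold higher number from compound 1 to compound 2 (0.92 log units; beyond the scatter) lies beyond the scatter, and its true size is left open by the limit. It replaces a different group with the 4-(methoxycarbonyl)phenyl group that compound 3 loses. On the strength of that step, a move to a lower number in this assay is expected, back towards the value of compound 1, 11900 nM. The expected change is an at least 4.0-fold lower number from compound 2 to compound 3 (0.60 log units; beyond the scatter). Compound 3 is expected at about 25000 nM, with an estimated range of 8000 nM to 90000 nM.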

Compound 3, concentration for 50% growth inhibition: 9750 nM
For compound 3 the middle estimate is 2.6-fold (0.41 log units) above the measured one, and the stated range covers the measured number.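

The change brings an at least 10-fold lower number from compound 2 to compound 3 (1.01 log units; beyond the scatter) in this assay, so the loss of growth inhibition seen with the 4-(methoxycarbonyl)phenyl group does not extend to every group at this place: with methyl on the same aromatic carbon, para to a large group, the value is again a measured number. Compared through a 1.2-fold lower number from compound 1 to compound 3 (0.09 log units; within the scatter), the 4-methylphenyl and 3-cyanophenyl groups on the carbonyl carbon cannot be told apart, which leaves the methoxycarbonyl compound as the only one of the three separated from the others beyond the scatter. The true size of the steps to compound 2 stays undetermined, because its reading is a limit of the assay and not a number: the limit of > 100000 nM in this assay, at which 1 of the 3 values shown sits.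

The compounds shown carry no carboxylic acid, amine or longer chain at this place, so it remains open whether the poor result belongs to methoxycarbonyl alone or to a wider set of groups. They also include no 4-cyanophenyl or 3-methylphenyl amide, so the effect of the group cannot be separated from that of its ring position.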